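Replacing the methoxypropyl chain of compound 1 with a ring

The compounds below may be only part of what the source reports. "The series", "measured", "known", "first", "only" and "open" are said of these compounds alone.

Among the measured compounds shown here, in an ADME assay on microsomes from liver (Rattus norvegicus) for metabolic stability, with a stated time of 10 min (a lower number here means that less of the compound is left, a higher number that more of the compound is left), compound 1 `COCCCc1cc(-c2ccc(Cl)cc2)n(-c2ccccc2OC)n1` gives 4% and stands lowest of the two numbers so far, while compound 2 `COc1ccccc1-n1nc(C2CCOC(C)(C)C2)cc1-c1ccc(Cl)cc1` gives 21% under the same conditions. Compound 3 `COc1ccccc1-n1nc([C@@H]2CCO[C@H](C(C)C)C2)cc1-c1ccc(Cl)cc1` is still unmeasured. It carries 2-isopropyloxan-4-yl in place of 3-methoxypropyl on an aromatic carbon. For the measured compounds named here, the one measured step that bears on this, with 2,2-dimethyloxan-4-yl entering instead, is modest and beyond the scatter (a number 17 percentage points higher from compound 1 to compound 2 (beyond the scatter)). A rise of similar size is therefore expected (a number 16 percentage points higher from compound 1 to compound 3 (beyond the scatter)). The expected value for compound 3 is 20% (range 7% to 40%).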

Compound 3, percent of the compound remaining: 21%
Estimate against measurement, compound 3: 1 percentage points below; low and high end bracket the measured number.
By their numbers in this assay, from the lowest: compound 1; then compounds 2 and 3 (each within the scatter of the next).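

In this assay, a second ring at this position gives a similar rise: a number 17 percentage points higher from compound 1 to compound 3 (beyond the scatter). The size and shape of the ring's branching make no visible difference here, with no change at the digits printed from compound 2 to compound 3 (within the scatter), so 2-isopropyloxan-4-yl and 2,2-dimethyloxan-4-yl cannot be told apart in this read-out. Nothing available explains the rise seen with either ring.

Still open, going by these compounds, is whether the ring is needed at all, or whether a plain oxan-4-yl ring or an amine such as piperidin-4-yl would serve equally well. On these data alone, the other stereoisomers of compound 3 also remain open.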